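The source may report more compounds than this note shows. Statements on the series, on what has been measured and on what is new or still open speak of the compounds shown alone.

Measured compounds:
compound 1 `NC(=O)[C@@H](CCC(F)(F)F)N(CC1COC1)S(=O)(=O)c1ccc(Cl)cc1` — 16.9 mL/min/kg
compound 2 `CC1(C)CO[C@H]1CN([C@H](CCC(F)(F)F)C(N)=O)S(=O)(=O)c1ccc(Cl)cc1` — 262 mL/min/kg
compound 3 `NC(=O)[C@@H](CCC(F)(F)F)N(C[C@@H]1COCCO1)S(=O)(=O)c1ccc(Cl)cc1` — 117 mL/min/kg

In an in vitro ADME assay on microsomes from liver (Homo sapiens) for metabolic stability, read by HPLC (a higher number here means faster removal of the compound, a lower number slower removal), compound 3 gives 117 mL/min/kg, the second highest of the three numbers. Its nearest neighbour is compound 2, with the step of a 2.2-fold lower number from compound 2 to compound 3 (0.35 log units; beyond the scatter); its furthest is compound 1, with the step of a 6.9-fold higher number from compound 1 to compound 3 (0.84 log units; beyond the scatter).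

Compound 4 `NC(=O)[C@@H](CCC(F)(F)F)N(C[C@H]1COCCO1)S(=O)(=O)c1ccc(Cl)cc1` differs from compound 3 in one respect: the two compounds have the same atoms and bonds and differ only in configuration as drawn: 1 of 2 stereo elements differ; a stereocentre at a saturated ring carbon is drawn R in compound 3 and S in compound 4. Within the data shown here, no measured step concerns a change of configuration alone; the two steps from compound 1, a 16-fold higher number from compound 1 to compound 2 (1.19 log units; beyond the scatter) and a 6.9-fold higher number from compound 1 to compound 3 (0.84 log units; beyond the scatter), each replace one ring by another. They therefore do not bear on this step. For compound 4 the expected step is no change at the digits printed from compound 3 to compound 4 (within the scatter), nothing beyond the scatter. The estimate for compound 4 is 117 mL/min/kg, within a range from 50 mL/min/kg to 270 mL/min/kg.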

Compound 4, clearance: 176 mL/min/kg
Beside the measured number, compound 4's estimate is 1.5-fold (0.18 log units) below it; the range from low to high includes it.
By their numbers in this assay, from the lowest: compound 1; then compounds 3, 4 and 2 (each within the scatter of the next, the first and the last beyond it).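

In this assay the step of a 1.5-fold higher number from compound 3 to compound 4 (0.18 log units; within the scatter) is the first measured change of configuration alone at this ring stereocentre, and it stays within the scatter: the fact that compounds 3 and 4 differ only in the configuration as drawn

The S-drawn 1,4-dioxan-2-yl compound also lies within the scatter of the 3,3-dimethyloxetan-2-yl compound, a 1.5-fold lower number from compound 2 to compound 4 (0.17 log units; within the scatter), but remains far from the oxetan-3-yl compound, a 10-fold higher number from compound 1 to compound 4 (1.02 log units; beyond the scatter), so that gap holds for both drawn configurations.

The compounds shown leave open whether a tetrahydrofuran ring or an open methoxyethyl chain in this place would give a number nearer to that of oxetan-3-yl or to that of 1,4-dioxan-2-yl.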